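Swapping the aryl group on the core nitrogen: compound 4

This account rests on a few compounds, and the source may have more. Where it says the series, first, only, none or still open, it means among the compounds named here.

Measured so far, in a functional assay on PC-12 cells (Rattus norvegicus) for cytotoxicity, read by MTT assay, with stated times of 2 h and 24 h, tested at 10 uM; a lower number here means a weaker effect, a higher number a stronger effect of the compound at the concentration tested:
- compound 1, `N#Cc1ccc(-n2nc(-c3ccc(C(F)(F)F)cc3O)nc2-c2ccccc2O)cc1`, gives 98.9%
- compound 2, `Oc1cc(C(F)(F)F)ccc1-c1nc(-c2ccccc2O)n(-c2ccccc2F)n1`, gives 100%
- compound 3, `Oc1cc(C(F)(F)F)ccc1-c1nc(-c2ccccc2O)n(-c2cccc(C(F)(F)F)c2)n1`, gives 99.9%

All three share the same core and differ only in the group carried on an aromatic nitrogen. Compound 3 stands second highest of the three numbers, but its neighbours sit so close that no order can be read: the step of a number 1 percentage points higher from compound 1 to compound 3 (within the scatter) and the step of a number 0.1 percentage points lower from compound 2 to compound 3 (within the scatter) are both within the scatter, as is a number 1.1 percentage points higher from compound 1 to compound 2 (within the scatter). In other words, every exchange of the group on this nitrogen tried so far has left the read-out essentially unchanged.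

Compound 4, `Cc1ccc(-n2nc(-c3ccc(C(F)(F)F)cc3O)nc2-c2ccccc2O)c(C)c1`, has not yet been measured. Its difference from compound 3 is 2,4-dimethylphenyl in place of 3-(trifluoromethyl)phenyl on an aromatic nitrogen. The two earlier exchanges at this same aromatic nitrogen bear directly on it and were both flat, so no change beyond the scatter is expected in this assay, and the expected step of a number 0.4 percentage points lower from compound 3 to compound 4 (within the scatter) is essentially nil. Compound 4 is therefore estimated at 99.5%, with a range from 95% to 100%.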

Compound 4, a percentage reported as activity, at one concentration (the size of the read-out at that concentration, not a potency): 106%
Compound 4: middle estimate off by 6.5 percentage points, on the low side; the whole stated range lies below it.
By their numbers in this assay, from the lowest: compounds 1, 3, 2 and 4 (each within the scatter of the next).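

In this assay, within the data shown here, the 2,4-dimethylphenyl group carries only carbon on its ring, whereas the earlier groups on this aromatic nitrogen bore a nitrile, a fluorine or a trifluoromethyl, yet the read-out shows a number 6.1 percentage points higher from compound 3 to compound 4 (within the scatter) and a number 6 percentage points higher from compound 2 to compound 4 (within the scatter) and a number 7.1 percentage points higher from compound 1 to compound 4 (within the scatter) with no step leaving the usual scatter. These steps are larger in size than those among compounds 1, 2 and 3, but the four compounds still cannot be put in a meaningful order, so all four aryl groups on this nitrogen give readings that cannot be told apart. Nothing available offers an explanation for the size of these steps.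

All four groups shown are substituted phenyl rings, so it remains open whether a carboxylic acid or an amine on that ring, or a plain alkyl chain in place of the ring, would give a reading clearly apart from these. The 2-hydroxyphenyl and 2-hydroxy-4-(trifluoromethyl)phenyl groups are the same in all four compounds, which leaves open what exchanging either of them, for example its hydroxyl for a methoxy group, would do to the read-out.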